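A Bromine for a Methyl on the Outer Ring

The compounds below may be only part of what the source reports. "The series", "measured", "known", "first", "only" and "open" are said of these compounds alone.

Three compounds share one core. Compound 1 `NS(=O)(=O)c1cccc(Nc2nccc(Nc3ccc4nc[nH]c4c3)n2)c1` is reported in an ADME assay on HepG2 cells (Homo sapiens) for inhibition, read by fluorescence and resazurin assay, with a stated time of 72 h (a higher number here means a weaker inhibitor, a lower number a stronger inhibitor), only as a limit, > 25000 nM, not as a number. Compound 2 `Cc1ccc(Nc2nccc(Nc3ccc4cn[nH]c4c3)n2)cc1` gives 18000 nM in this assay. Compound 3 `Cc1cccc(Nc2ncc([N+](=O)[O-])c(Nc3ccc4nc[nH]c4c3)n2)c1` gives 22000 nM, and the numbers of compound 2 and compound 3 lie within the scatter of each other, so neither can be called weaker or stronger. Compound 4 `Brc1ccc(Nc2nccc(Nc3ccc4cn[nH]c4c3)n2)cc1` has not yet been measured; it differs from compound 2 in one place: bromo in place of methyl on an aromatic carbon. Within the data shown here, no measured pair shows what this exchange does, and the known spread of numbers is narrow, bounded by the limit of > 25000 nM in this assay, at which 1 of the 3 values shown sits. The step from compound 2 to compound 4 is expected to be a 1.2-fold lower number from compound 2 to compound 4 (0.08 log units; within the scatter) in this assay, no larger than the scatter. Compound 4 is therefore estimated at 15000 nM, between 6000 nM and 40000 nM.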

Compound 4, half-maximal inhibitory concentration: 20000 nM
Compound 4: the middle estimate sits 1.3-fold (0.12 log units) below what was measured; low and high end bracket the measured number.
By their numbers in this assay, from the lowest: compounds 2, 4 and 3 (each within the scatter of the next). At a limit, above all of these: compound 1.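

The exchange of 4-methylphenyl for 4-bromophenyl now has a measured size in this assay: a 1.1-fold higher number from compound 2 to compound 4 (0.05 log units; within the scatter). At this position of the outer ring, then, methyl and bromo cannot be told apart by this read-out. The room for seeing any change is also narrow: the limit of > 25000 nM in this assay, at which 1 of the 4 values shown sits.

On these data alone, what an amine or a carboxylic acid at the same position would do stays open. So does whether any group placed here can move the number beyond the scatter.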